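The source may hold more compounds than are shown below. What is called first, only, known or untested is meant among the compounds shown, and "the series" means these compounds.

Measured compounds:
compound 1 `Nc1ccccc1NC(=O)c1ccc(CSC(=S)N2CCN(c3cccnc3)CC2)cc1` — in a functional assay on A-375 cells (Homo sapiens) for antiproliferative activity, read by CCK-8 assay, with a stated time of 72 h, tested at 2 uM (a higher number here means a stronger effect of the compound at the concentration tested, a lower number a weaker effect), compound 1 gives 40.5%
compound 2 `Nc1ccccc1NC(=O)c1ccc(CSC(=S)N2CCN(c3ccc(F)cc3)CC2)cc1` — compound 2 gives 20.9%
compound 3 `Cc1ccc(N2CCN(C(=S)SCc3ccc(C(=O)Nc4ccccc4N)cc3)CC2)cc1` — compound 3 gives 25.8%

Compound 3 stands second highest of the three; its gap to compound 2 is within the scatter, its gap to compound 1 is beyond it, a number 14.7 percentage points lower from compound 1 to compound 3 (beyond the scatter).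

Compound 4 `Nc1ccccc1NC(=O)c1ccc(CSC(=S)N2CCN(c3ccncc3)CC2)cc1` is not yet measured. It differs from compound 3 in one place: pyridin-4-yl in place of 4-methylphenyl on an amine nitrogen in a ring.

Within the data shown here, the step that bears on this is the one from the pyridin-3-yl compound to the 4-methylphenyl compound, a number 14.7 percentage points lower from compound 1 to compound 3 (beyond the scatter), with a number 19.6 percentage points lower from compound 1 to compound 2 (beyond the scatter) pointing the same way. Reversing that step, an increase of similar size is expected, a number 10.2 percentage points higher from compound 3 to compound 4 (beyond the scatter), though the pyridin-4-yl ring is not the ring tested in compound 1. Compound 4 is expected to give 36%, in the range 22% to 50%.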

Compound 4, a percentage reported as inhibition, at one concentration (the size of the read-out at that concentration, not a potency): 85.7%
Compound 4: middle estimate off by 49.7 percentage points, on the low side; measured number above the stated range.
By their numbers in this assay, from the lowest: compounds 2 and 3 (each within the scatter of the next); then compound 1; then compound 4.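

In this assay, the placing of the nitrogen within the aromatic ring on the ring amine nitrogen matters strongly: moving to pyridin-4-yl gives a number 45.2 percentage points higher from compound 1 to compound 4 (beyond the scatter) for two compounds that differ only in that placing. The carbon-only rings trail further, with a number 59.9 percentage points higher from compound 3 to compound 4 (beyond the scatter) against 4-methylphenyl and a number 64.8 percentage points higher from compound 2 to compound 4 (beyond the scatter) against 4-fluorophenyl, so a pyridine ring as such does not account for the level of compound 4. No measured property of these compounds is available to explain the jump.

Open, from the compounds shown here alone, is whether pyridin-2-yl or pyrimidin-5-yl on the same nitrogen keeps this level. A single-concentration read-out also leaves the potency of compound 4 undefined.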